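The compounds below may be only part of what the source reports. "The series", "measured", "known", "first", "only" and "open" are said of these compounds alone.

Compound 1 `Cc1cccc(N2CCN(C(=O)CN3C(=O)CC(C)(c4ccccc4)C3=O)CC2)c1` and compound 2 `COc1ccccc1N1CCN(C(=O)CN2C(=O)CC(C)(c3ccccc3)C2=O)CC1` share one core and differ only in the group carried on the amine nitrogen in the ring. In a functional assay on the whole organism (strain CD-1) with Mus musculus as the target, in the maximal electroshock model, with a stated time of 2 h (on this read-out higher numbers stand for an effect only at larger amounts of compound and lower numbers for an effect already at smaller amounts), compound 1 gives 300 mg/kg, and in this assay compound 2 gives 300 mg/kg. The step of no change at the digits printed from compound 1 to compound 2 (within the scatter) shows that swapping the group on that ring nitrogen left the read-out where it was. Within the data shown here, compound 2 therefore stands level with compound 1 on the numbers so far, with nothing to separate the two. Compound 3 `CC1(c2ccccc2)CC(=O)N(CC(=O)N2CCN(c3ccc(Cl)c(Cl)c3)CC2)C1=O` has not yet been measured in this assay. Its structure differs from compound 2 as follows: 3,4-dichlorophenyl in place of 2-methoxyphenyl on an amine nitrogen in a ring. Among the measured compounds shown here, the only measured step that bears on this change is the exchange of the group on the same ring nitrogen, and that step was flat. On this basis the expected step of no change at the digits printed from compound 2 to compound 3 (within the scatter) is none beyond the scatter. The estimate for compound 3 in this assay is 300 mg/kg, with a range from 150 mg/kg to 600 mg/kg. For the measured compounds named here, this expectation rests on a single step, and a move to the 3,4-dichlorophenyl group has no direct precedent among the measured compounds.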

Compound 3, minimum effective dose: 300 mg/kg
Beside the measured number, compound 3's estimate shows no gap at the digits printed, and the stated range covers the measured number.
By their numbers in this assay, from the lowest: compounds 1, 2 and 3 (each within the scatter of the next).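

In this assay the exchange of 2-methoxyphenyl for 3,4-dichlorophenyl on the amine nitrogen in the ring gives no change at the digits printed from compound 2 to compound 3 (within the scatter) on this read-out, and the exchange of 3-methylphenyl for the same group gives no change at the digits printed from compound 1 to compound 3 (within the scatter) as well. The earlier pair covered only a methyl-bearing and a methoxy-bearing phenyl, whereas these steps extend the flat result at this position to a phenyl carrying chlorine, with 0 hydrogen-bond acceptors in the entering group against 1 in the 2-methoxyphenyl group it replaces. Nothing at hand offers an explanation for this flat read-out.

The compounds shown leave open whether the read-out on this nitrogen moves at all with a group of another kind, such as a benzyl group or a phenyl ring bearing a carboxylic acid. They also leave open whether the same flat result would hold if the methyl group on the shared core gave way to an ethyl group.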